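Trifluoromethyl removal on the bicyclic amide of compound 2

The source may hold more compounds than are shown below. What is called first, only, known or untested is meant among the compounds shown, and "the series" means these compounds.

Measured compounds:
- compound 1 `Cc1cc(N(C)C)ccc1-c1nnc(N(C)Cc2ccc3nccn3c2)o1`: 15800 nM
- compound 2 `CNC(=O)c1sc(N2CC3CC2(CNC(=O)c2c[nH]c4ncc(C(F)(F)F)cc24)C3)nc1C(F)(F)F`: 25.1 nM
- compound 3 `C[C@@H]1CN(c2cnc(Nc3cc(F)c(OCC4CC4)c(F)c3)nc2NC2CCOCC2)CCN1`: 1580 nM

In an assay on isolated protein for inhibition of tyrosine-protein kinase receptor UFO (Homo sapiens), read by LC-MS, with stated times of 30 min and 180 min (a higher number here means a weaker inhibitor, a lower number a stronger inhibitor), compound 2 gives 25.1 nM, the lowest number of the three measured, with its gaps to compound 3 and compound 1 both beyond the scatter, so compound 2 is the strongest inhibitor here. Among the compounds with values here, compound 1 and compound 3 share no scaffold with compound 2, so no single-change step between measured compounds is available.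

The next compound, compound 4 `CNC(=O)c1sc(N2CC3CC2(CNC(=O)c2c[nH]c4ncccc24)C3)nc1C(F)(F)F`, keeps the whole of compound 2 apart from one change: hydrogen in place of trifluoromethyl on an aromatic carbon. The change is confined to the bicyclic amide part, two atoms from the ring nitrogen.

With no measured step of this kind in the series, the size of the effect is uncertain. Removing a trifluoromethyl group from a close analogue of a potent compound is most often neutral to mildly weakening; the expected step from compound 2 to compound 4 is a 2.5-fold higher number from compound 2 to compound 4 (0.40 log units; beyond the scatter), a small loss, toward a higher number. Compound 4 is therefore estimated at 63 nM, with a range from 20 nM to 200 nM.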

Compound 4, half-maximal inhibitory concentration in the tyrosine-protein kinase receptor UFO assay: 10 nM
Compound 4: middle estimate off by 6.3-fold (0.80 log units), on the high side, outside the stated range (below it).
By their numbers in the tyrosine-protein kinase receptor UFO assay, from the lowest: compound 4; then compound 2; then compound 3; then compound 1.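

Within the data shown here, at this aromatic carbon, two atoms from the ring nitrogen, trifluoromethyl is not required for inhibition in the tyrosine-protein kinase receptor UFO assay and its removal gives the first single-change step: hydrogen in its place gives a 2.5-fold lower number from compound 2 to compound 4 (0.40 log units; beyond the scatter) and leaves compound 4 the lowest number so far. In a physicochemical assay for solubility (on this read-out higher numbers stand for higher solubility and lower numbers for lower solubility), compound 2 gives < 1600 nM as a limit of the assay. In the physicochemical assay compound 4 gives < 1600 nM as a limit too, and the step on this read-out cannot be read: the limit of < 1600 nM in the physicochemical assay, at which 2 of the 2 values shown sit.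

Still open, as far as these compounds go, is whether a methyl, a nitrile or an amine at this carbon would hold or lower the number seen with hydrogen. The compounds shown also leave open whether the change has any effect on solubility, and what the second trifluoromethyl of the shared core contributes.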